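Chain change on the shared core: compound 1 to compound 4

The source may report more compounds than this note shows. Statements on the series, on what has been measured and on what is new or still open speak of the compounds shown alone.

Compound 1 `CN(C)CCNc1nc(-c2ccc(NC(=O)Nc3ccccc3)cc2)nc2ccsc12` carries the unsubstituted phenylurea on the shared core. For the measured compounds named here, in a functional assay on MKN-45 cells (Homo sapiens) for cytotoxicity, read by MTT assay, with a stated time of 72 h (on this read-out higher numbers stand for weaker inhibition and lower numbers for stronger inhibition), compound 1 gives 1120 nM, the highest of the three numbers measured so far. Compound 2 `CN(C)CCNc1nc(-c2ccc(NC(=O)Nc3ccccc3F)cc2)nc2ccsc12` gives 530 nM in this assay, and the step of a 2.1-fold lower number from compound 1 to compound 2 (0.32 log units; beyond the scatter). Compound 3 `CN(C)CCNc1nc(-c2ccc(NC(=O)Nc3ccccc3Cl)cc2)nc2ccsc12` gives 850 nM; the step of a 1.3-fold lower number from compound 1 to compound 3 (0.12 log units; within the scatter), and the step of a 1.6-fold higher number from compound 2 to compound 3 (0.21 log units; within the scatter).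

Compound 4 `CCN(CC)CCCNc1nc(-c2ccc(NC(=O)Nc3ccccc3)cc2)nc2ccsc12` is not yet measured. It keeps the unsubstituted phenylurea of compound 1 and differs from it only in the chain: (diethylamino)methyl in place of dimethylamino on a saturated chain carbon, two bonds along the chain from a nitrogen on an aromatic ring. The three measured steps all concern the ring of the urea and leave the chain untouched, so none of them bears on the change from compound 1 to compound 4. Going by the values given here, the data give no step of this kind at all. The expectation therefore rests on compound 1 alone, whose value of 1120 nM serves as the anchor, and the range must be set wide.

Compound 4 is expected to give about 1000 nM in this assay, within an estimated range of 300 nM to 3500 nM. The expected step is a 1.1-fold lower number from compound 1 to compound 4 (0.05 log units; within the scatter), that is, no step beyond the scatter is expected in either direction.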

Compound 4, half-maximal inhibitory concentration: 980 nM
Compound 4: the middle estimate sits 1.0-fold (0.01 log units) above what was measured; measured number inside the range.
By their numbers in this assay, from the lowest: compounds 2, 3, 4 and 1 (each within the scatter of the next, the first and the last beyond it).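

In this assay, for the compounds shown here, the first change at the chain rather than the urea ring gives a 1.1-fold lower number from compound 1 to compound 4 (0.06 log units; within the scatter). Going by these compounds alone, on the unsubstituted phenylurea, then, (3-(diethylamino)propyl)amino in place of (2-(dimethylamino)ethyl)amino, with 6 heavy atoms entering where 3 leave, gives no step beyond the scatter, and this single pair is the only reading of this position so far. No measurement accompanies the result that could tie this outcome to any property of the two chains.

The exchange alters the length of the chain and the groups on its terminal nitrogen together, so a 3-(dimethylamino)propyl or a 2-(diethylamino)ethyl chain on the same core would be needed to separate those two parts, and a chain ending in a morpholine, a piperidine or a carboxylic acid would test whether the terminal amine matters at all. As far as these compounds go, whether the same chain exchange also gives no step beyond the scatter when the urea ring carries the fluoro of compound 2 or the chloro of compound 3 remains open as well.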